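A few compounds are considered here, and "the series" means these few. Any claim that something is new, unique, unknown or untested is made for them only; others in the source may bear on it.

Compound 1 `Cc1c(OCCCCOc2ccc(C(=O)O)c(Cl)c2)ccc(C(=O)CC(C)C)c1O` stands second highest of the three numbers in an assay on HEK293 cells for positive allosteric modulation of metabotropic glutamate receptor 3 (Rattus norvegicus), read by thallium flux, with a stated time of 2.5 min (on this read-out lower numbers stand for smaller maximal responses and higher numbers for larger maximal responses), where compound 1 gives 49.5%. Nearest to it is compound 3 `Cc1c(OCCCCOc2ccc(C(=O)O)c(Cl)c2)ccc(C(=O)CC2CCCC2)c1O`, which gives 40%; the step of a number 9.5 percentage points lower from compound 1 to compound 3 (within the scatter) lies within the scatter. Furthest off is compound 2 `COc1ccc(C(=O)O)cc1OCCCCOc1ccc(C(=O)CC(C)C)c(O)c1C`, which gives 100%, beyond the scatter from compound 1, though compound 2 differs from compound 1 in more than one place, so only the two values can be set side by side. Compound 4 `Cc1c(OCCCCOc2ccc(C(=O)O)cc2F)ccc(C(=O)CC(C)C)c1O` differs from compound 1 by 4-carboxy-2-fluorophenyl in place of 4-carboxy-3-chlorophenyl on an oxygen on a saturated carbon. Among the compounds with values here, no measured step touches the part of the structure that changes here, so no shift beyond the scatter is expected, with a wide range given the spread among the three compounds. For compound 4 the expected result is 55% (range 30% to 90%), an expected step of a number 5.5 percentage points higher from compound 1 to compound 4 (within the scatter).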

Compound 4, largest response reached (reported as percent of maximum), in percent of the reference or control that the assay uses: 67.7%
Estimate against measurement, compound 4: 12.7 percentage points below, and the stated range covers the measured number.
By their numbers in this assay, from the lowest: compounds 3 and 1 (each within the scatter of the next); then compound 4; then compound 2.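

In this assay, within the data shown here, the step of a number 18.2 percentage points higher from compound 1 to compound 4 (beyond the scatter) shows that the maximal response responds to a change at this place, which no earlier step had touched. Fluorine replaces chlorine and its place on the ring changes in the same step, so the two changes cannot be told apart here. Nothing available explains the rise. From the compounds shown here alone, it stays open whether 4-carboxy-3-fluorophenyl, which would separate the two changes, gives a similar response. Also open, going by these compounds, is whether an amide in place of the carboxylic acid keeps the response.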